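The source may hold more compounds than are shown below. What is called first, only, known or untested is meant among the compounds shown, and "the series" means these compounds.

Measured compounds:
compound 1 `CCn1c(/C=C2\SC(=O)N(CC(=O)N3CCCC3)C2=O)nc2ccccc21`, a functional assay on DU-145 cells (Homo sapiens) for inhibition, read by MTT assay, with a stated time of 48 h (a lower number here means a stronger inhibitor, a higher number a weaker inhibitor), 45100 nM
compound 2 `CCn1c(/C=C2\SC(=O)N(CC(=O)N3CCc4cc(OC)c(OC)cc4C3)C2=O)nc2ccccc21`; in this assay compound 2 reaches only the limit of the assay, > 50000 nM
compound 3 `CC(C)n1c(/C=C2\SC(=O)N(CC(=O)N3CCCC3)C2=O)nc2ccccc21`; in this assay compound 3 likewise gives only a limit, > 50000 nM

The difference between the two cores, compound 1 against compound 2, is not broken down here. The change methyl in place of hydrogen on a saturated chain carbon bound to an aromatic nitrogen and a saturated chain carbon gives an at least 1.1-fold higher number from compound 1 to compound 3 (0.04 log units; that floor lies within the scatter), and its floor is set by the limit of > 50000 nM in this assay, at which 2 of the 3 values shown sit. Compound 4 `COc1cc2c(cc1OC)CN(C(=O)CN1C(=O)S/C(=C\c3nc4ccccc4n3C(C)C)C1=O)CC2` is not yet measured; it carries the same change, (methyl in place of hydrogen on a saturated chain carbon bound to an aromatic nitrogen and a saturated chain carbon), on the core of compound 2. Because compound 2 already sits at the limit of > 50000 nM in this assay, at which 2 of the 3 values shown sit, and the earlier step only moved towards weaker inhibition, compound 4 is expected to remain a limit, with the step that the limit leaves unreadable from compound 2 to compound 4. The estimate for compound 4 in this assay is 70000 nM, between 40000 nM and 200000 nM.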

Compound 4, half-maximal inhibitory concentration: 29700 nM
Estimate against measurement, compound 4: 2.4-fold (0.37 log units) above; measured number outside the range, below it.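

Ethyl to isopropyl on the core of compound 2 gives an at least 1.6-fold lower number from compound 2 to compound 4 (0.22 log units; that floor lies within the scatter) in this assay. Set beside the same change on the core of compound 1, this shows no transfer from one core to the other and no failure to transfer: the same change on two cores in this assay, an at least 1.1-fold higher number (0.04 log units; that floor lies within the scatter) from compound 1 to compound 3 and an at least 1.6-fold lower number (0.22 log units; that floor lies within the scatter) from compound 2 to compound 4; the limit leaves it open whether they differ. Each step has one end at a limit, so neither has a full size, and a real difference between the two cores is neither shown nor excluded: the limit of > 50000 nM in this assay, at which 2 of the 4 values shown sit.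

Still open, as far as these compounds go, is how a longer chain, such as n-butyl in place of isopropyl, would read on either core. Also open, from the compounds shown here alone, is whether the change behaves alike on a core carrying a carboxylic acid or an amine.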